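Two measured compounds and a thiophene regiochemistry swap

The compounds below may be only part of what the source reports. "The series", "measured", "known", "first", "only" and "open" are said of these compounds alone.

Compound 1: `Clc1ccc(-c2cc(-c3ccsc3)nc(-c3ccccc3Cl)c2)o1` — 8070 nM
Compound 2: `Clc1ccc(-c2cc(-c3cccnc3)nc(-c3cccs3)c2)o1` — 14600 nM

Among the measured compounds shown here, the two compounds measured so far were tested in a functional assay on HeLa cells (Homo sapiens) for cytotoxicity, in the presence of a further agent that is not named here; a lower number here means a stronger inhibitor, a higher number a weaker inhibitor. In that assay compound 1 gives 8070 nM, and compound 2 gives 14600 nM. Compound 2 carries the higher of the two numbers, but its nearest neighbour compound 1 sits within the usual scatter of it, so the two values cannot be ranked against each other. For the measured compounds named here, the two compounds differ in more than one place, so no single step between them can be isolated.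

The next compound, compound 3 `Clc1ccc(-c2cc(-c3cccnc3)nc(-c3ccsc3)c2)o1`, keeps the same atoms as compound 2 but joins them differently: thiophen-3-yl in place of thiophen-2-yl on an aromatic carbon. The group leaving and the group entering are both a five-membered aromatic ring with one hetero atom, so the change is a shift in the point of attachment of the thiophene. Going by the values given here, no step of this kind between measured compounds is available. The change is expected to stay within the scatter, with no clear direction. Compound 3 is therefore estimated to come out near compound 2, at 12000 nM (range 4000 nM to 35000 nM), which corresponds to an expected step of a 1.2-fold lower number from compound 2 to compound 3 (0.09 log units; within the scatter).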

Compound 3, half-maximal inhibitory concentration: > 50000 nM
Compound 3 gave a limit, no number (the forecaster's own chance of this, stated with the estimate: 10%); at least 4.1-fold (0.61 log units) between middle value and limit.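

In this assay compound 3 gives no number but a limit of the assay: the limit of > 50000 nM in this assay, at which 1 of the 3 values shown sits.

The shift of the thiophene's point of attachment, thiophen-3-yl in place of thiophen-2-yl next to the ring nitrogen, gives an at least 3.4-fold higher number from compound 2 to compound 3 (0.53 log units; beyond the scatter), so this position responds to how the ring is joined even though the atoms and the counts of the group stay the same. With thiophen-3-yl held in place, pyridin-3-yl in place of 2-chlorophenyl gives an at least 6.1-fold higher number from compound 1 to compound 3 (0.79 log units; beyond the scatter), and compound 1 therefore shows that thiophen-3-yl does not bring the limit on its own, since it keeps a measured value alongside 2-chlorophenyl.

From the compounds shown here alone, how far compound 3 lies beyond its limit stays open, so both steps give only a lower bound on their size. Also open, going by these compounds, is how the position next to the ring nitrogen would respond to a group other than a thiophene, such as a phenyl ring, or to a thiophene carrying an amine or a carboxylic acid.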